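The compounds below may be only part of what the source reports. "The series", "measured", "known", "first", "only" and "open" are said of these compounds alone.

Series in a functional assay on SGC-7901 cells (Homo sapiens) for cytotoxicity, read by sulforhodamine B assay, with a stated time of 72 h; on this read-out lower numbers stand for stronger inhibition and higher numbers for weaker inhibition:
compound 1 `C=C1C(=O)O[C@@H]2CC(C)=C([C@@H](C)CCCOC(C)=O)[C@@H](OC(=O)CN3CCCC3)[C@H]12` gives 18400 nM
compound 2 `C=C1C(=O)O[C@@H]2CC(C)=C([C@@H](C)CCCOC(C)=O)[C@@H](OC(=O)COc3cccc(C(C)=O)c3)[C@H]12` gives 46100 nM
compound 3 `C=C1C(=O)O[C@@H]2CC(C)=C([C@@H](C)CCCOC(C)=O)[C@@H](OC(=O)COc3ccc(C(C)=O)cc3)[C@H]12` gives 49600 nM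

Compound 3 carries the highest of the three numbers; the step of a 1.1-fold higher number from compound 2 to compound 3 (0.03 log units; within the scatter) is within the scatter, whereas compound 1 lies lower, with a 2.7-fold higher number from compound 1 to compound 3 (0.43 log units; beyond the scatter) and a 2.5-fold higher number from compound 1 to compound 2 (0.40 log units; beyond the scatter) both modest. Compound 4 `C=C1C(=O)O[C@@H]2CC(C)=C([C@@H](C)CCCOC(C)=O)[C@@H](OC(=O)COc3cccc4cccnc34)[C@H]12` is unmeasured; the change is quinolin-8-yl in place of 4-acetylphenyl on an oxygen on a saturated carbon. The step bearing most directly on it is a 1.1-fold higher number from compound 2 to compound 3 (0.03 log units; within the scatter), an exchange of one aryl group for another on the same oxygen, which moved nothing beyond the scatter. The larger steps from compound 1 concern a different change, the loss of pyrrolidin-1-yl, and do not carry over. The expectation for compound 4 is therefore a step of a 1.1-fold lower number from compound 3 to compound 4 (0.04 log units; within the scatter) within the scatter. Compound 4 is estimated at 45000 nM, range 18000 nM to 110000 nM.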

Compound 4, half-maximal inhibitory concentration: 14300 nM
Estimate against measurement, compound 4: 3.1-fold (0.50 log units) above, and the stated range ends above it.
By their numbers in this assay, from the lowest: compounds 4 and 1 (each within the scatter of the next); then compounds 2 and 3 (each within the scatter of the next).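

On the oxygen on a saturated carbon, the aryl group does count in this assay, with a 3.5-fold lower number from compound 3 to compound 4 (0.54 log units; beyond the scatter) and a 3.2-fold lower number from compound 2 to compound 4 (0.51 log units; beyond the scatter) both beyond the scatter, whereas a 1.1-fold higher number from compound 2 to compound 3 (0.03 log units; within the scatter) between the two acetylphenyl groups was not. With a 1.3-fold lower number from compound 1 to compound 4 (0.11 log units; within the scatter) within the scatter, (quinolin-8-yl)oxy and pyrrolidin-1-yl cannot be told apart on the saturated chain carbon bound to a carbonyl carbon. No measurement at hand accounts for the quinolin-8-yl result.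

As far as these compounds go, whether the step comes from the nitrogen of quinolin-8-yl or from its second ring stays open; naphthalen-1-yl on the same oxygen would separate the two.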